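This account rests on a few compounds, and the source may have more. Where it says the series, first, only, none or still open, it means among the compounds named here.

This study follows a set of compounds built on a shared core and asks how strongly each one holds back the growth of a human colon cancer cell line. In a functional assay on COLO 205 cells (Homo sapiens) for antiproliferative activity, read by sulforhodamine B assay, with a stated time of 72 h (on this read-out higher numbers stand for weaker inhibition and lower numbers for stronger inhibition), compound 1 `Cc1ccc(C(/C=C/c2ccc(F)cc2)=N\Nc2nncc3ccccc23)cc1` gives 6.8 nM. Compound 2 `NC(=S)NNc1nncc2ccccc12` gives 55 nM in this assay. Compound 3 `O=S(=O)(Nc1ccccn1)c1ccc(Nc2nncc3ccccc23)cc1`, a sulfonamide carrying a pyridin-2-yl group, gives 44 nM in this assay. Among these three numbers compound 3 holds the second highest. Its nearest neighbour is compound 2, whose value lies within the usual scatter of such measurements, so the two cannot be told apart on the evidence at hand; compound 1, by contrast, shows a clearly lower number, a gap that lies beyond the scatter.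

Compound 4 `O=S(=O)(Nc1ncccn1)c1ccc(Nc2nncc3ccccc23)cc1` has not yet been measured. It differs from compound 3 in one place only: pyrimidin-2-yl in place of pyridin-2-yl on a sulfonamide nitrogen. Going by the values given here, no measured pair in this set shows the same exchange, so its effect has to be guessed rather than read off. A change confined to one ring of this size is expected to shift the number only modestly, and the step of a 1.1-fold lower number from compound 3 to compound 4 (0.04 log units; within the scatter) is expected to stay within the scatter. Compound 4 is accordingly estimated at 40 nM, with a likely range from 15 nM to 120 nM.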

Compound 4, half-maximal inhibitory concentration: 43 nM
Compound 4: middle estimate off by 1.1-fold (0.03 log units), on the low side; low and high end bracket the measured number.
By their numbers in this assay, from the lowest: compound 1; then compounds 4, 3 and 2 (each within the scatter of the next).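

In this assay, placing pyrimidin-2-yl where pyridin-2-yl stood on a sulfonamide nitrogen gives a 1.0-fold lower number from compound 3 to compound 4 (0.01 log units; within the scatter) and so leaves the two compounds indistinguishable on this read-out. Going by these compounds alone, this is the first direct comparison at this position, which the earlier compounds could not offer: a six-membered aromatic ring with 1 hetero atom and one with 2 hetero atoms, the second counting 2 hydrogen-bond acceptors against 1, give numbers that cannot be told apart here. Nothing available explains why these two rings read alike, and equal numbers in a cell growth test do not by themselves show that the two compounds behave alike in every other respect.

On these data alone, only these two rings are compared at this place, so it remains open whether a smaller group such as a methyl, a plain phenyl ring or a ring-bound carboxylic acid on the sulfonamide nitrogen would also leave the number in the same range. Compound 1 and compound 2 differ from this pair in more than one place, so the compounds shown do not reveal which structural feature accounts for any difference in their values.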